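Changing the Sulfonamide Heterocycle on Two Different Cores

The compounds below may be only part of what the source reports. "The series", "measured", "known", "first", "only" and "open" are said of these compounds alone.

Compound 1 `O=C1/C(=C/c2coc3ccccc3c2=O)N=C(c2ccc(Cl)cc2)N1c1ccc(S(=O)(=O)Nc2nccs2)cc1` and compound 3 `Cc1cc(C)nc(NS(=O)(=O)c2ccc(N3C(=O)/C(=C/c4coc5ccccc5c4=O)N=C3c3ccc(Cl)cc3)cc2)n1` share one core, and compound 3 differs from compound 1 by 4,6-dimethylpyrimidin-2-yl in place of 1,3-thiazol-2-yl on a sulfonamide nitrogen. In a functional assay on MCF7 cells (Homo sapiens) for cytotoxicity, read by sulforhodamine B assay, with a stated time of 72 h (a lower number here means a stronger inhibitor, a higher number a weaker inhibitor), compound 1 gives > 100000 nM, which is a limit of the assay rather than a number. In this assay compound 3 gives 93900 nM. The change made an at least 1.0-fold lower number from compound 1 to compound 3 (0.02 log units; that floor lies within the scatter), and both values sit at or close to the limit of > 100000 nM in this assay, at which 2 of the 3 values shown sit.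

Compound 2 `O=C1N=C(Nc2ccc(S(=O)(=O)Nc3nccs3)cc2)S/C1=C/c1coc2ccccc2c1=O` has a different core; the difference between the two cores is not broken down here. In this assay compound 2 gives > 100000 nM, a limit. Compound 4 `Cc1cc(C)nc(NS(=O)(=O)c2ccc(NC3=NC(=O)/C(=C\c4coc5ccccc5c4=O)S3)cc2)n1` differs from compound 2 by 4,6-dimethylpyrimidin-2-yl in place of 1,3-thiazol-2-yl on a sulfonamide nitrogen, the same change at the same place. From compound 2 to compound 4 the expected step is a number no higher from compound 2 to compound 4 (the limit leaves the size open), resting on an at least 1.0-fold lower number from compound 1 to compound 3 (0.02 log units; that floor lies within the scatter) and on the limit of compound 2 in this assay. Compound 4 is expected to give about 100000 nM, between 60000 nM and 200000 nM.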

Compound 4, half-maximal inhibitory concentration: > 100000 nM
Compound 4: a limit, no number (the forecaster's own chance of this, stated with the estimate: 70%); the middle value lies on the limit itself.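

Compound 2 and compound 4 both give a limit of the assay rather than a number, so no step can be read between them. As far as these compounds go, whether 4,6-dimethylpyrimidin-2-yl in place of 1,3-thiazol-2-yl changes the result in this assay on the core of compound 2 stays open.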